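Aryl urea swap in the A-375 inhibition series

This account rests on a few compounds, and the source may have more. Where it says the series, first, only, none or still open, it means among the compounds named here.

Measured so far:
compound 1 `CC1CN(C(=O)c2ccc(-c3ccc(NC(=O)Nc4ccc(Cl)c(C(F)(F)F)c4)cc3)cc2)CC(C)O1`: > 50000 nM (a limit)
compound 2 `CC(NC(=O)CCc1ccc(NC(=O)Nc2ccc(Cl)c(C(F)(F)F)c2)cc1)c1ccccc1`: > 50000 nM (a limit)
compound 3 `CC(NC(=O)/C=C/Oc1ccc(NC(=O)Nc2cc(C(F)(F)F)ccc2Cl)cc1)c1ccccc1`: 16000 nM

In a functional assay on A-375 cells (Homo sapiens) for inhibition, read by MTT assay, with a stated time of 120 h (on this read-out lower numbers stand for stronger inhibition and higher numbers for weaker inhibition), compound 3 gives 16000 nM, the only number shown in the series. Compound 1 reaches only the limit of this assay, > 50000 nM. Compound 2 likewise sits at the limit, > 50000 nM. Two of the three values thus stop at this limit (the limit of > 50000 nM in this assay, at which 2 of the 3 values shown sit).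

Compound 4 `CC(NC(=O)/C=C/Oc1ccc(NC(=O)Nc2ccc(Cl)c(C(F)(F)F)c2)cc1)c1ccccc1` is not yet measured. It differs from compound 3 in one place: 4-chloro-3-(trifluoromethyl)phenyl in place of 2-chloro-5-(trifluoromethyl)phenyl on an amide-type nitrogen. Among the compounds with values here, no step between measured compounds matches this change. Compounds 1 and 2 carry the entering group and both stop at the limit, though they differ elsewhere too. The step of a 1.3-fold higher number from compound 3 to compound 4 (0.10 log units; within the scatter) is expected to be small and, if anything, toward weaker inhibition. Compound 4 is estimated at 20000 nM, in the range 5000 nM to 60000 nM.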

Compound 4, half-maximal inhibitory concentration: 20700 nM
Beside the measured number, compound 4's estimate is 1.0-fold (0.01 log units) below it; the range from low to high includes it.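

In this assay, within the data shown here, 4-chloro-3-(trifluoromethyl)phenyl in place of 2-chloro-5-(trifluoromethyl)phenyl on an amide-type nitrogen gives the first step that can be read, a 1.3-fold higher number from compound 3 to compound 4 (0.11 log units; within the scatter). With the rest of the structure unchanged, this exchange of two groups of the same atoms does not separate the pair. Compound 4 also shows the entering group with a measured number, which compounds 1 and 2 did not give: the limit of > 50000 nM in this assay, at which 2 of the 4 values shown sit.

Open, going by these compounds, is whether an unsubstituted phenyl, or a phenyl carrying a nitrile in place of the chlorine, would move the number beyond the scatter at this place.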